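Furan for Phenyl on an Inactive Nucleoside Core

A few compounds are considered here, and "the series" means these few. Any claim that something is new, unique, unknown or untested is made for them only; others in the source may bear on it.

The series centres on a shared core carrying a sugar and a substituted aromatic ring. Compound 2 `CNc1ncnc2c1c(-c1ccccc1)cn2[C@@H]1O[C@H](CO)[C@@H](O)[C@H]1O` was tested in a functional assay on HCT-116 cells (Homo sapiens), read by MTT assay, with a stated time of 72 h (a higher number here means a weaker inhibitor, a lower number a stronger inhibitor), and there compound 2 reached only the limit of > 20000 nM, which is a limit of the assay and not a number. Compound 1 `CN(C)c1ncnc2c1c(-c1ccoc1)cn2[C@@H]1O[C@H](CO)[C@@H](O)[C@H]1O` likewise gave only the limit of > 20000 nM in this assay. Thus compound 2 stands at the limit of > 20000 nM in this assay, at which 2 of the 2 values shown sit, with no compound measured below it. Compound 3 `CNc1ncnc2c1c(-c1ccoc1)cn2[C@@H]1O[C@H](CO)[C@@H](O)[C@H]1O` has not yet been measured in this assay. It differs from compound 2 by furan-3-yl in place of phenyl on an aromatic carbon. Going by the values given here, with no measured step between compounds to draw on, the step that the limit leaves unreadable from compound 2 to compound 3 is expected to be none beyond the scatter, leaving compound 3 at the limit. Compound 3 is therefore estimated at 25000 nM, within a range from 8000 nM to 80000 nM, with a reported limit rather than a number the most likely outcome.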

Compound 3, half-maximal inhibitory concentration: > 20000 nM
Compound 3 was reported as a limit; the forecaster's own chance of this, stated with the estimate: 85%; the middle value does not contradict the limit.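

Compound 3 also gave only a limit in this assay and not a number, so its steps from compound 2 and from compound 1 cannot be read: the limit of > 20000 nM in this assay, at which 3 of the 3 values shown sit. The compounds shown leave open whether either change, furan-3-yl for phenyl or hydrogen for methyl on the nitrogen, makes any difference in this assay.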